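A Single Swap on the Carbonyl Carbon

The source may report more compounds than this note shows. Statements on the series, on what has been measured and on what is new or still open speak of the compounds shown alone.

Compound 1 `Cn1c(-c2ccccc2)cnc1NC(=O)c1ccc(Cl)cc1`: > 100000 nM (a limit)
Compound 2 `COc1ccc(-c2cnc(NC(=O)c3cccc(Br)c3)n2C)cc1`: > 100000 nM (a limit)

Both entries come from a toxicity assay on THP-1 cells (Homo sapiens) for inhibition (a higher number here means that more compound is tolerated, a lower number that less compound is tolerated), and each is a limit of the assay rather than a number. Compound 2 stands at the limit of > 100000 nM in this assay, at which 2 of the 2 values shown sit. Among the measured compounds shown here, no exact value is therefore known for compound 2, and no step between measured compounds is available to show how large a structural change might be.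

Compound 3 `COc1ccc(-c2cnc(NC(=O)c3ccc(Cl)cc3)n2C)cc1` differs from compound 2 in one place: 4-chlorophenyl in place of 3-bromophenyl on a carbonyl carbon. Here, 4-chlorophenyl takes the place of 3-bromophenyl on a carbonyl carbon, while the rest of the structure stays the same.

The expectation rests on compound 2, whose limit is > 100000 nM. No change beyond the usual scatter is expected in this assay, in either direction, and a reading at the same limit is the likeliest outcome. The expected step is a number no higher from compound 2 to compound 3 (the limit leaves the size open). For compound 3 the estimate is 100000 nM, with an expected range from 50000 nM to 200000 nM.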

Compound 3, half-maximal cytotoxic concentration: > 100000 nM
Compound 3: no number, only a limit; the forecaster's own chance of this, stated with the estimate: 85%; the middle value lies on the limit itself.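

In this assay compound 3 gives only a limit, as do compound 1 and compound 2, and neither the step from compound 2 to compound 3 nor the step from compound 1 to compound 3 can be read: the limit of > 100000 nM in this assay, at which 3 of the 3 values shown sit.

The compounds shown leave open the exact tolerated concentration of each, and whether either swap changes it at all.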